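The compounds below may be only part of what the source reports. "The series", "measured", "known", "first", "only" and "open" are said of these compounds alone.

Measured compounds in a functional assay on the whole organism (strain albino) for inhibition, with Rattus norvegicus as the target, read by paw edema, with stated times of 30 min and 5 h, at a dose of 100 mg/kg by the oral route; on this read-out lower numbers stand for less inhibition and higher numbers for more inhibition at the one dose given (going by the name of the read-out):
Compound 1, `Nc1ccc(C(=O)/C=C/c2ccc(Cl)cc2)cc1`, gives 54%.
Compound 2, `O=C(CO[N+](=O)[O-])Nc1ccc(C(=O)/C=C/c2ccc(Cl)cc2)cc1`, gives 60%.
Compound 3, `O=C(CO[N+](=O)[O-])Nc1ccc(C(=O)/C=C/c2ccco2)cc1`, gives 39%.

Compound 2 carries the highest of the three numbers, but its standing is uneven. Toward compound 3 the step is beyond the scatter: a number 21 percentage points lower from compound 2 to compound 3 (beyond the scatter). Toward compound 1, on the other hand, the two values cannot be ordered, since the step that installed the whole side chain stayed within the scatter: a number 6 percentage points higher from compound 1 to compound 2 (within the scatter).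

Compound 4, `CC(O[N+](=O)[O-])C(=O)Nc1ccc(C(=O)/C=C/c2ccc(Cl)cc2)cc1`, differs from compound 2 by methyl in place of hydrogen on a saturated chain carbon bound to a carbonyl carbon and an oxygen on an unsaturated carbon. Cut one bond further out, the change reads (nitrooxy)methyl to 1-(nitrooxy)ethyl. For the measured compounds named here, the only measured step that touches this side chain is the one that introduced it, and that step was within the scatter. Going by the values given here, no measured step alters the saturated chain carbon itself, so the data give no direction for this change. The expected step of a number 2 percentage points lower from compound 2 to compound 4 (within the scatter) is therefore small and within the scatter. For compound 4 the estimated value in this assay is 58%, expected to fall between 45% and 70%.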

Compound 4, a percentage reported as inhibition, in the whole organism at one dose (the size of the read-out at that dose, not a potency): 56%
The estimate for compound 4 lay 2 percentage points above the measured number, within the range that was stated.
By their numbers in this assay, from the lowest: compound 3; then compounds 1, 4 and 2 (each within the scatter of the next).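

In this assay, methyl on the saturated chain carbon bound to a carbonyl carbon and an oxygen on an unsaturated carbon gives a step that stays within the scatter (a number 4 percentage points lower from compound 2 to compound 4 (within the scatter)). This is the only change at that carbon among these compounds, and it shows that going from (nitrooxy)methyl to 1-(nitrooxy)ethyl has no readable effect at this dose, while the branched side chain also cannot be told apart from the bare amine (a number 2 percentage points higher from compound 1 to compound 4 (within the scatter)). Nothing available here offers an explanation for this result.

The compounds shown leave open whether an ethyl, a phenyl or a second methyl on that carbon would move the number beyond the scatter. They also leave open what a hydroxyl in place of the nitrooxy group would do, and whether methyl reads the same with furan-2-yl in place of 4-chlorophenyl.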